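Replacing a short ether chain with a branched aromatic group

A few compounds are considered here, and "the series" means these few. Any claim that something is new, unique, unknown or untested is made for them only; others in the source may bear on it.

Compound 1 `C[C@@H](Oc1cc2oc(=O)n(CCC(=O)O)c2cc1Cl)c1ccc(Cl)cn1`: 100 nM
Compound 2 `COCCOc1cc2oc(=O)n(CCC(=O)O)c2cc1Cl`: 50100 nM

Within the data shown here, only two compounds have been measured. In an assay on HEK293 cells for inhibition of kynurenine 3-monooxygenase (Homo sapiens), read by LC-MS, with a stated time of 20 h (a lower number here means a stronger inhibitor, a higher number a weaker inhibitor), compound 1 gives 100 nM, and compound 2 gives 50100 nM. Compound 2 therefore stands at the highest of the two numbers, which makes it the weaker inhibitor, and its distance from compound 1 lies well beyond the usual scatter. Among the measured compounds shown here, the two differ in more than one place, so no single step links them.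

Compound 3 `C[C@@H](Oc1cc2oc(=O)n(CCC(=O)O)c2cc1Cl)c1ncco1` is derived from compound 2 by a group of 7 heavy atoms (5 carbon, 1 nitrogen, 1 oxygen; one five-membered aromatic ring with 2 hetero atoms) in place of a group of 4 heavy atoms (3 carbon, 1 oxygen; no ring), on an oxygen on an aromatic ring. The new group resembles the branched aromatic group that compound 1 carries on the same oxygen, with a methyl-bearing stereocentre next to that oxygen, though the ring itself is a different one.

A large move toward lower numbers in this assay is expected for compound 3, because compound 1 with a related branched aromatic group gives 100 nM while compound 2 gives 50100 nM, so the step of a 170-fold lower number from compound 2 to compound 3 (2.22 log units; beyond the scatter) is expected. Compound 3 is estimated at 300 nM, within a range of 60 nM to 2000 nM.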

Compound 3, half-maximal inhibitory concentration: 7940 nM
Compound 3: middle estimate off by 26-fold (1.42 log units), on the low side; the whole stated range lies below it.
By their numbers in this assay, from the lowest: compound 1; then compound 3; then compound 2.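

In this assay, putting the methyl-bearing 1,3-oxazol-2-yl group in place of 2-methoxyethyl on the oxygen on an aromatic ring gives a 6.3-fold lower number from compound 2 to compound 3 (0.80 log units; beyond the scatter) and so counts as a modest gain, well short of what the branched group of compound 1 suggested. With the methyl-bearing chain carbon and its defined stereocentre kept, 1,3-oxazol-2-yl in place of 5-chloropyridin-2-yl gives a 79-fold higher number from compound 1 to compound 3 (1.90 log units; beyond the scatter) and is a large loss, which shows that the branched chain alone does not bring the low number of compound 1 and that the ring it carries matters a great deal at this position. Nothing available here explains why these two rings differ so strongly.

The compounds shown do not separate the chlorine of 5-chloropyridin-2-yl from the ring that carries it, and a plain pyridin-2-yl or a phenyl group on the same chain carbon would speak to that question. On these data alone, the part played by the methyl also stays open, and a plain methylene link or the opposite stereocentre would test it.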